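The compounds below may be only part of what the source reports. "The series", "measured", "known", "first", "only" and "open" are said of these compounds alone.

In a functional assay on HCT-116 cells (Homo sapiens) for inhibition, read by CCK-8 assay, with a stated time of 72 h, tested at 2 uM (on this read-out lower numbers stand for less inhibition of growth and higher numbers for more inhibition of growth at the one concentration tested), compound 1 (`COc1ccc(SCc2ccc(/C=C/C(=O)Nc3ccccc3N)cc2)cc1OC`) gives 12.9% and compound 2 (`Nc1ccccc1NC(=O)/C=C/c1ccc(CSc2ccc(C(F)(F)F)cn2)cc1`) gives 4.42%. Among the measured compounds shown here, compound 2 therefore stands within the scatter of compound 1, the only other measured compound, and the two cannot be ranked.

The next structure is compound 3 (`Nc1ccccc1NC(=O)/C=C/c1ccc(CSc2ccc(F)cc2)cc1`), with this change from compound 2: 4-fluorophenyl in place of 5-(trifluoromethyl)pyridin-2-yl on a sulfur. It places 4-fluorophenyl in place of 5-(trifluoromethyl)pyridin-2-yl on a sulfur whose other neighbour is a saturated chain carbon.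

For the measured compounds named here, only one measured step bears on this. It exchanges 3,4-dimethoxyphenyl for 5-(trifluoromethyl)pyridin-2-yl on the same sulfur, and it reads a number 8.5 percentage points lower from compound 1 to compound 2 (within the scatter). With a single step of that size, no shift beyond the scatter is expected in this assay. Compound 3 shares with compound 1 an aromatic ring of carbon only on the sulfur, so any drift is expected to be slightly upward, though the data cannot establish this.

Going by the values given here, the expected change is a number 4.6 percentage points higher from compound 2 to compound 3 (within the scatter), which would be no real step. For compound 3 the estimated value is 9%, with an expected range of 1% to 22%.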

Compound 3, percent growth inhibition at one concentration: 14.1%
Compound 3: the middle estimate sits 5.1 percentage points below what was measured, within the range that was stated.
By their numbers in this assay, from the lowest: compounds 2, 1 and 3 (each within the scatter of the next).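

On the sulfur whose other neighbour is a saturated chain carbon, 4-fluorophenyl gives a number 9.7 percentage points higher from compound 2 to compound 3 (within the scatter) in this assay, and it gives a number 1.2 percentage points higher from compound 1 to compound 3 (within the scatter), both within the scatter. With three aromatic groups now read at this position, all three steps among them lie within the scatter, so 4-fluorophenyl, 3,4-dimethoxyphenyl and 5-(trifluoromethyl)pyridin-2-yl cannot be ranked, and neither a ring of carbon only nor a ring with a hetero atom sets itself apart on this read-out. No measurement is at hand that would explain the values of these compounds.

Among the compounds shown here, the series so far holds only six-membered aromatic rings on the sulfur, so it remains open whether a non-aromatic group there, such as a piperidine, a longer alkyl chain or a chain ending in a carboxylic acid, would give a step beyond the scatter. Also open, from the compounds shown here alone, is whether an amine or a hydroxyl on the aromatic ring would move the number, and whether oxygen in place of the sulfur itself would do so.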